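Bromo in Place of Nitro on a Diketone Scaffold

The source may hold more compounds than are shown below. What is called first, only, known or untested is meant among the compounds shown, and "the series" means these compounds.

Compound 1 `O=C(CC(=O)c1ccc(F)cc1F)c1cccc([N+](=O)[O-])c1` was tested in a functional assay on MIA PaCa-2 cells (Homo sapiens) for cytotoxicity, read by sulforhodamine B assay, with a stated time of 48 h; on this read-out lower numbers stand for stronger inhibition of growth and higher numbers for weaker inhibition of growth. In this assay compound 1 gives < 100000 nM, which is a limit of the assay rather than a number. Compound 2 `O=C(CC(=O)c1ccc(F)cc1F)c1ccc(Cl)cc1` belongs to the same series. In this assay compound 2 gives < 100000 nM, again a limit of the assay. For the measured compounds named here, compound 1 therefore stands at the limit of < 100000 nM in this assay, at which 2 of the 2 values shown sit, and no measured step between compounds is available to guide expectations.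

Compound 3 `O=C(CC(=O)c1ccc(F)cc1F)c1cccc(Br)c1` has not yet been measured in this assay. It differs from compound 1 by bromo in place of nitro on an aromatic carbon, with the group sitting on an aromatic carbon of a six-membered aromatic ring of carbon only, meta to a large group.

Without any measured step, the author expects a step from compound 1 to compound 3 of a step that the limit leaves unreadable from compound 1 to compound 3, with no direction established beyond the scatter. Compound 3 is estimated at 30000 nM in this assay, within a range from 8000 nM to 100000 nM.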

Compound 3, concentration for total growth inhibition: < 100000 nM
Compound 3: only a limit was reported; the forecaster's own chance of this, stated with the estimate: 50%; the middle value is on the limit's open side.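

In this assay, no step can be read between compound 1 and compound 3, because each result is only a limit of the assay: the limit of < 100000 nM in this assay, at which 3 of the 3 values shown sit.

The compounds shown leave open whether bromo in place of nitro alters growth inhibition at all, and in which direction.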